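The source may hold more compounds than are shown below. What is called first, only, known or untested is meant among the compounds shown, and "the series" means these compounds.

Compound 1 `O=C(Nc1cccc(S(=O)(=O)C2CCCC2)c1)c1cccnc1N1CCC(F)(F)CC1` was tested in an ADME assay on microsomes from liver (Mus musculus) for metabolic stability, read by LC-MS, with a stated time of 40 min, tested at 0.5 uM; on this read-out higher numbers stand for fast clearance and lower numbers for slow clearance. Compound 1 gives > 399 mL.min-1.g-1, which is a limit of the assay and not a number. Compound 2 `CC(C)(C)NS(=O)(=O)c1cccc(NC(=O)c2ccc(NC(C)(C)CO)cc2N2CCC3(CC2)CC3)n1` gives > 399 mL.min-1.g-1, again a limit. Going by the values given here, both values therefore sit at one limit, (the limit of > 399 mL.min-1.g-1 in this assay, at which 2 of the 2 values shown sit), and no measured step is available. Compound 3 `O=C(Nc1cccc(S(=O)(=O)C2CCCC2)c1)c1cccnc1N1CCC2(CC1)CC2` keeps the core of compound 1 but changes one group, on an aromatic carbon next to the ring nitrogen, ortho to a large group: a group of 8 heavy atoms (7 carbon, 1 nitrogen; one three-membered non-aromatic ring of carbon only, one six-membered non-aromatic ring with 1 hetero atom) in place of a group of 8 heavy atoms (5 carbon, 1 nitrogen, 2 fluorine; one six-membered non-aromatic ring with 1 hetero atom), on an aromatic carbon. The 4,4-difluoropiperidin-1-yl group leaves, and a group with one three-membered non-aromatic ring of carbon only and one six-membered non-aromatic ring with 1 hetero atom enters. The expectation rests on compound 1 at > 399 mL.min-1.g-1, a limit. The estimated step that the limit leaves unreadable from compound 1 to compound 3 lies within the usual scatter, so clearance in this assay is expected to stay fast. For compound 3 the expected value is 400 mL.min-1.g-1, with an estimated range from 200 mL.min-1.g-1 to 800 mL.min-1.g-1.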

Compound 3, intrinsic clearance in microsomes: > 399 mL.min-1.g-1
Compound 3 was reported as a limit (the forecaster's own chance of this, stated with the estimate: 70%); the middle value does not contradict the limit.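

In this assay compound 1 and compound 3 both stand at a limit, so no step can be read between them: the limit of > 399 mL.min-1.g-1 in this assay, at which 3 of the 3 values shown sit.

The compounds shown leave open what their clearance actually is, and so whether replacing the 4,4-difluoropiperidin-1-yl group changes it at all.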